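A few compounds are considered here, and "the series" means these few. Any claim that something is new, unique, unknown or untested is made for them only; others in the source may bear on it.

Working notes on the aryl group on the amide-type nitrogen. Compound 1 `COc1cc2nc([S+]([O-])CC(=O)Nc3ccc(C#N)cc3)nc(Nc3c(Cl)cc(/C=C/C#N)cc3Cl)c2cc1OC` gives >= 188000 nM in an ADME assay on MT4 cells (Homo sapiens) for cytotoxicity, read by MTT assay, with a stated time of 5 days (on this read-out higher numbers stand for lower toxicity in this test and lower numbers for higher toxicity in this test), and this value is a limit of the assay, not a number. In this assay compound 2 `COc1cc2nc([S+]([O-])CC(=O)Nc3cccc(S(N)(=O)=O)c3)nc(Nc3c(Cl)cc(/C=C/C#N)cc3Cl)c2cc1OC` gives 67800 nM, and compound 3 `COc1cc2nc([S+]([O-])CC(=O)Nc3c(C)cc(C)cc3C)nc(Nc3c(Cl)cc(/C=C/C#N)cc3Cl)c2cc1OC` gives 8870 nM. For the measured compounds named here, compound 3 therefore holds the lower of the two exact numbers, which means the higher toxicity in this test, and it stands below every other compound measured so far.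

Compound 4 `COc1cccc(NC(=O)C[S+]([O-])c2nc(Nc3c(Cl)cc(/C=C/C#N)cc3Cl)c3cc(OC)c(OC)cc3n2)c1` has 3-methoxyphenyl in place of 2,4,6-trimethylphenyl on an amide-type nitrogen. Going by the values given here, three measured steps bear on this change. Two of them enter 2,4,6-trimethylphenyl: a 7.6-fold lower number from compound 2 to compound 3 (0.88 log units; beyond the scatter) is modest and an at least 21-fold lower number from compound 1 to compound 3 (1.32 log units; beyond the scatter) is large. The third, an at least 2.7-fold lower number from compound 1 to compound 2 (0.44 log units; beyond the scatter), involves neither group of the new change but shows that a change of aryl group alone can move the number beyond the scatter. Among the compounds with values here, no measured compound carries 3-methoxyphenyl, so the size of the step remains uncertain. Leaving 2,4,6-trimethylphenyl is the reverse of a 7.6-fold lower number from compound 2 to compound 3 (0.88 log units; beyond the scatter), so a modest rise is expected. The expected step is a 3.4-fold higher number from compound 3 to compound 4 (0.53 log units; beyond the scatter). For compound 4 the estimated value is 30000 nM, with an expected range of 11000 nM to 90000 nM.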

Compound 4, half-maximal cytotoxic concentration: >= 167000 nM
Compound 4: only a limit was reported; the forecaster's own chance of this, stated with the estimate: 10%; at least 5.5-fold (0.74 log units) between middle value and limit.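

In this assay compound 4 gives >= 167000 nM, a limit of the assay and not a number, so 3-methoxyphenyl joins the 4-cyanophenyl of compound 1 as a second aryl group on the amide-type nitrogen that reaches a limit. Leaving 2,4,6-trimethylphenyl gives an at least 18-fold higher number from compound 3 to compound 4 (1.27 log units; beyond the scatter), which is large, while methoxy in place of sulfamoyl on an aromatic carbon gives an at least 2.4-fold higher number from compound 2 to compound 4 (0.39 log units; beyond the scatter), so compound 3 now stands apart from all three other compounds, with the lowest number and so the higher toxicity in this test. The step between compound 1 and compound 4 cannot be read, as both values are limits, and no order between these two can be stated.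

Still open, from the compounds shown here alone, is whether the low number of compound 3 needs all the methyl groups of 2,4,6-trimethylphenyl or follows from only some of them. Also open, going by these compounds, is how an amine or a carboxylic acid on the aryl ring, or a longer chain in place of the aryl group, would move the number in this assay.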